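Amide-type nitrogen: 1H-1,2,4-triazol-3-yl in place of 2-carboxyethyl

The source may report more compounds than this note shows. Statements on the series, on what has been measured and on what is new or still open speak of the compounds shown alone.

In a functional assay on cells (Mast cell, Rattus norvegicus) for inhibition, with a stated time of 15 min (a higher number here means that more compound is needed for the effect, a lower number that less compound is needed), compound 1 `O=C(Nc1nnn[nH]1)c1cc(=O)c2ccccc2o1` gives 0.08 ug/mL. Compound 2 `O=C(O)CCNC(=O)c1cc(=O)c2ccccc2o1` gives > 18 ug/mL, which is a limit of the assay and not a number. Its true position is therefore unknown. Compound 3 `O=C(Nc1nc[nH]n1)c1cc(=O)c2ccccc2o1` has 1H-1,2,4-triazol-3-yl in place of 2-carboxyethyl on an amide-type nitrogen. The entering group is one five-membered aromatic ring with 3 hetero atoms, and compound 3 thereby moves back towards the 1H-tetrazol-5-yl of compound 1. Among the measured compounds shown here, the one measured step bearing on this is an at least 220-fold higher number from compound 1 to compound 2 (2.35 log units; beyond the scatter), which is large and beyond the scatter. A large fall in the number is thus expected in this assay, though probably without full recovery, since the ring differs from that of compound 1. The expected change is an at least 18-fold lower number from compound 2 to compound 3 (1.25 log units; beyond the scatter). For compound 3 the estimated value is 1 ug/mL, with an expected range of 0.1 ug/mL to 12 ug/mL.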

Compound 3, concentration for half-maximal effect: 5 ug/mL
Beside the measured number, compound 3's estimate is 5.0-fold (0.70 log units) below it; the measured number falls inside the stated range.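

In this assay, a five-membered aromatic ring on the amide-type nitrogen does not by itself carry the low number of compound 1: exchanging its 1H-tetrazol-5-yl for 1H-1,2,4-triazol-3-yl gives a 63-fold higher number from compound 1 to compound 3 (1.80 log units; beyond the scatter), so this position distinguishes between two closely related rings. The ring of compound 3 still improves on the open chain, with an at least 3.6-fold lower number from compound 2 to compound 3 (0.55 log units; beyond the scatter). That step is only a minimum size, because the entry for compound 2 is a limit of the assay and not a number: the limit of > 18 ug/mL in this assay, at which 1 of the 3 values shown sits.

Going by these compounds, it remains open where a ring with fewer nitrogens, such as imidazol-2-yl, or a plain phenyl would fall on this nitrogen. Also open, on these data alone, is whether a carboxylic acid on a shorter chain, such as carboxymethyl, would give a measurable value in place of a limit.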